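Growing the Linker from Compound 3 to Compound 4

A few compounds are considered here, and "the series" means these few. Any claim that something is new, unique, unknown or untested is made for them only; others in the source may bear on it.

Compound 1 `Nc1ncnc2c1c(-c1cnc3[nH]ccc3c1)nn2CCCCCCC(=O)NO`: 10300 nM
Compound 2 `Nc1nc2cc(-c3nn(CCCC(=O)NO)c4ncnc(N)c34)ccc2o1`: > 50000 nM
Compound 3 `Nc1ncnc2c1c(-c1cnc3[nH]ccc3c1)nn2CC(=O)NO`: > 150000 nM

In a functional assay on HepG2 cells (Homo sapiens) for inhibition, read by MTT assay, with a stated time of 72 h (on this read-out lower numbers stand for stronger inhibition and higher numbers for weaker inhibition), compound 3 sits at a limit, not at a measured number. Compound 2 likewise stands at a limit in this assay. Among the compounds with values here, compound 1 is the only one of the three with a measured value, and the one comparable step, an at least 14-fold higher number from compound 1 to compound 3 (1.16 log units; beyond the scatter), came with the chain cut shorter. Compound 4 `Nc1ncnc2c1c(-c1cnc3[nH]ccc3c1)nn2CCC(=O)NO` differs from compound 3 by (hydroxycarbamoyl)methyl in place of hydroxycarbamoyl on a saturated chain carbon bound to an aromatic nitrogen. Lengthening the chain again points in the direction opposite to that step, so a modest gain at most is expected, with a fair chance that only a limit is reported. Compound 4 is therefore estimated at 120000 nM, within 40000 nM to 400000 nM, an expected step of an at least 1.2-fold lower number from compound 3 to compound 4 (0.09 log units; that floor lies within the scatter).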

Compound 4, half-maximal inhibitory concentration: > 150000 nM
Compound 4 was reported as a limit; the forecaster's own chance of this, stated with the estimate: 65%; at least 1.2-fold (0.09 log units) between middle value and limit.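

The step from compound 3 to compound 4 cannot be read, because both compounds sit at the same limit: the limit of > 150000 nM in this assay, at which 2 of the 4 values shown sit. Measured against the longest chain shown, the 2-(hydroxycarbamoyl)ethyl chain gives an at least 14-fold higher number from compound 1 to compound 4 (1.16 log units; beyond the scatter). So in this assay, one added chain carbon does not bring back a measured value, and a short chain here stays well behind the chain of compound 1.

Still open, as far as these compounds go, is the chain length at which a measured value first appears on the core of compound 1, for example with a 3-(hydroxycarbamoyl)propyl chain, and whether a longer chain than that of compound 1 would give a lower number.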